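Swapping the aryl for cyclopentyl on the shared core

A few compounds are considered here, and "the series" means these few. Any claim that something is new, unique, unknown or untested is made for them only; others in the source may bear on it.

Among the compounds with values here, compound 1 `C=CC(=O)Nc1cc(Nc2ncc3ncn(-c4ccc(F)cc4)c3n2)c(OC)cc1N(C)CCN(C)C` gives 12000 nM in an ADME assay on HT-29 cells (Homo sapiens) for cytotoxicity, read by MTT assay, with a stated time of 72 h (a lower number here means a stronger inhibitor, a higher number a weaker inhibitor), the higher of the two numbers known so far. Compound 2 `C=CC(=O)Nc1cc(Nc2ncc3ncn(-c4ccc(Br)cc4)c3n2)c(OC)cc1N(C)CCN(C)C` gives 1460 nM in this assay, a step of an 8.2-fold lower number from compound 1 to compound 2 (0.91 log units; beyond the scatter). Compound 3 `C=CC(=O)Nc1cc(Nc2ncc3ncn(C4CCCC4)c3n2)c(OC)cc1N(C)CCN(C)C` differs from compound 1 by cyclopentyl in place of 4-fluorophenyl on an aromatic nitrogen. Within the data shown here, no measured step covers this change; the bromo-for-fluoro step shows only that a change at this place can move the number well beyond the scatter. The expected step is therefore a 2.0-fold lower number from compound 1 to compound 3 (0.30 log units; within the scatter), carrying wide uncertainty. Compound 3 is estimated at 6000 nM, between 1500 nM and 25000 nM.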

Compound 3, half-maximal inhibitory concentration: 20900 nM
For compound 3 the middle estimate is 3.5-fold (0.54 log units) below the measured one; low and high end bracket the measured number.
By their numbers in this assay, from the lowest: compound 2; then compounds 1 and 3 (each within the scatter of the next).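

Cyclopentyl on the aromatic nitrogen shows that, in this assay, a non-aromatic ring can take the place of 4-fluorophenyl with the number staying within the scatter (a 1.7-fold higher number from compound 1 to compound 3 (0.24 log units; within the scatter)). The same cyclopentyl set against 4-bromophenyl gives a large step (a 14-fold higher number from compound 2 to compound 3 (1.16 log units; beyond the scatter)), so an aromatic ring at this position does not by itself set the number: among these three compounds, only compound 2 stands apart. No evidence is available that accounts for either step. The compounds shown leave open how a 4-chlorophenyl group, an amine on the phenyl ring or a longer chain on this nitrogen would read in this assay.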